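A Methylpiperazine on a Growth-Silent Pair

This account rests on a few compounds, and the source may have more. Where it says the series, first, only, none or still open, it means among the compounds named here.

Compound 1 `Cc1ccccc1Nc1nc(Nc2ccccc2)ncc1Cl` gives > 100000 nM as a limit
Compound 2 `Cc1ccc(Nc2ncc(Cl)c(Nc3ccccc3C)n2)cc1` gives > 100000 nM as a limit

In a functional assay on MDA-MB-231 cells (Homo sapiens) for inhibition, read by CCK-8 assay, with a stated time of 48 h (on this read-out higher numbers stand for weaker inhibition of growth and lower numbers for stronger inhibition of growth), compound 2 stands only at the limit > 100000 nM and gives no number. Compound 3 `Cc1ccccc1Nc1nc(Nc2ccc(N3CCN(C)CC3)cc2)ncc1Cl` differs from it as follows: 4-methylpiperazin-1-yl in place of methyl on an aromatic carbon in one change. Going by the values given here, the only measured step bearing on this is a step that the two limits leave unreadable from compound 1 to compound 2 and it sets no size. Among the compounds with values here, with the limit of > 100000 nM in this assay, at which 2 of the 2 values shown sit, as the sole guide, any readable change can only run toward stronger inhibition. The expected step is an at least 8.3-fold lower number from compound 2 to compound 3 (0.92 log units; beyond the scatter) in that direction, and this is a loose estimate. Compound 3 is estimated at 12000 nM with 2000 nM to 70000 nM as its expected range.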

Compound 3, concentration for 50% growth inhibition: 7020 nM
For compound 3 the middle estimate is 1.7-fold (0.23 log units) above the measured one; low and high end bracket the measured number.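

In this assay, 4-methylpiperazin-1-yl in place of methyl on this aromatic carbon gives an at least 14-fold lower number from compound 2 to compound 3 (1.15 log units; beyond the scatter), and the same group in place of hydrogen gives an at least 14-fold lower number from compound 1 to compound 3 (1.15 log units; beyond the scatter). Methyl on this carbon left no readable step, whereas this group brings the series its first actual number. Both sizes remain lower bounds only, because the starting values are limits: the limit of > 100000 nM in this assay, at which 2 of the 3 values shown sit.

The compounds shown leave open what a morpholine ring or an unsubstituted piperazine on this carbon would give. They also leave open whether the methyl on the piperazine nitrogen contributes to the step.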